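Swapping bromo for hydroxy on compound 1

This account rests on a few compounds, and the source may have more. Where it says the series, first, only, none or still open, it means among the compounds named here.

Compound 1 `O=c1c(Br)cc2ccccc2n1Cc1nc2ccccc2n1CCCCF` gives 26200 nM
Compound 2 `CC(C)CCn1c(CN2C(=O)CS(=O)(=O)c3ccccc32)nc2ccccc21` gives 63000 nM
Compound 3 `CC(C)CCn1c(CN2C(=O)C(CC(=O)O)c3ccccc32)nc2ccccc21` gives 16500 nM

For the measured compounds named here, all three values come from an ADME assay on HEp-2 cells (Homo sapiens) for cytotoxicity (on this read-out higher numbers stand for lower toxicity in this test and lower numbers for higher toxicity in this test), and no measured pair differs in one place only. Compound 1 sits within the scatter of compound 3, while compound 2 has the higher number, beyond the scatter of compound 1. Compound 4 `O=c1c(O)cc2ccccc2n1Cc1nc2ccccc2n1CCCCF` carries hydroxy in place of bromo on an aromatic carbon of the core of compound 1 (hydroxy in place of bromo on an aromatic carbon). Going by the values given here, no measured compound shows what this change does, so only a small step is expected in this assay. The estimate stays anchored on compound 1 at 26200 nM as its starting point. The expected step runs a 1.1-fold higher number from compound 1 to compound 4 (0.06 log units; within the scatter) and stays within the scatter. Compound 4 is estimated at 30000 nM with an expected range from 12000 nM to 75000 nM for its measurement.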

Compound 4, half-maximal cytotoxic concentration: 20200 nM
The estimate for compound 4 lay 1.5-fold (0.17 log units) above the measured number; the measured number falls inside the stated range.
By their numbers in this assay, from the lowest: compounds 3, 4 and 1 (each within the scatter of the next); then compound 2.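

In this assay, for the compounds shown here, the only step measured at this position runs a 1.3-fold lower number from compound 1 to compound 4 (0.11 log units; within the scatter), so hydroxy in place of bromo on an aromatic carbon of the core leaves the read-out within the scatter. For this one pair, a hydrogen-bond donor and acceptor enter with no step beyond the scatter. Nothing at hand explains the size of this step. On these data alone, whether an amine, a methoxy group or a carboxylic acid at this position would also stay within the scatter remains open. So does whether the same swap would behave alike on another core.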